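This account rests on a few compounds, and the source may have more. Where it says the series, first, only, none or still open, it means among the compounds named here.

Series notes, step from compound 2 to compound 4.

The series shares one core; in a functional assay on CHO-K1 cells for antagonist activity at adenosine receptor A1 (Homo sapiens), read by a beta-galactosidase reporter and cAMP accumulation, with stated times of 15 min and 6 h (on this read-out lower numbers stand for stronger inhibition and higher numbers for weaker inhibition), compound 1 `Cc1ccc(-c2nc(N)c3cc(-c4ccccc4)sc3n2)o1` gives 520 nM. Compound 2 `Cc1ccc(-c2nc(N)c3cc(Cc4ccccc4)sc3n2)o1` gives 298 nM in this assay, and compound 3 `COc1ccccc1Cc1cc2c(N)nc(-c3ccc(C)o3)nc2s1` gives 122 nM. On these three numbers compound 2 holds the second highest; its nearest neighbour is compound 1, the step of a 1.7-fold lower number from compound 1 to compound 2 (0.24 log units; within the scatter) lying within the scatter, and its furthest is compound 3, reached by the step of a 2.4-fold lower number from compound 2 to compound 3 (0.39 log units; beyond the scatter), a modest step beyond the scatter.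

Compound 4 `Nc1nc(C2CCCO2)nc2sc(Cc3ccccc3)cc12` is not yet measured in this assay. It differs from compound 2 only in the group between two ring nitrogen atoms of the core: oxolan-2-yl in place of 5-methylfuran-2-yl on an aromatic carbon. Neither measured step bears on this place; both concern the group on the other ring of the core, where a benzyl replaced a phenyl and a methoxy replaced a hydrogen. For the measured compounds named here, there is therefore no direct precedent; the change swaps an aromatic five-membered ring for a non-aromatic one and removes the methyl, and a step to a higher number beyond the scatter is expected, though with wide uncertainty. The step of a 3.0-fold higher number from compound 2 to compound 4 (0.48 log units; beyond the scatter) is the expected outcome. Compound 4 is estimated at 900 nM in this assay, within a range from 300 nM to 3000 nM.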

Compound 4, inhibition constant: 2950 nM
Estimate against measurement, compound 4: 3.3-fold (0.52 log units) below; low and high end bracket the measured number.
By their numbers in this assay, from the lowest: compound 3; then compounds 2 and 1 (each within the scatter of the next); then compound 4.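

In this assay, the group between two ring nitrogen atoms is the first place in the series shown to respond strongly, with a 9.9-fold higher number from compound 2 to compound 4 (1.00 log units; beyond the scatter), a larger step than a 2.4-fold lower number from compound 2 to compound 3 (0.39 log units; beyond the scatter), which is the larger of the two earlier steps and arises elsewhere on the core. The two groups exchanged here are alike in being five-membered rings with one hetero atom and in their hydrogen-bond donor and acceptor counts, so this match in counts does not preserve the number; what changes is an aromatic ring becoming a non-aromatic one, together with the loss of the methyl group. Nothing available gives a reason for the size of this step.

The compounds shown leave open how much of the step belongs to the ring and how much to the methyl group, a question that furan-2-yl, lacking the methyl group, or 5-methyloxolan-2-yl, keeping it on the non-aromatic ring, would separate. Also open, on these data alone, are how a phenyl ring or a cyclic amine such as pyrrolidin-1-yl would fare at this place, and whether the step carries over to the 2-methoxybenzyl compound 3.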